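Solubility notes: hydroxyethyl piperidine replacing carbamoylmethyl piperazine

This account rests on a few compounds, and the source may have more. Where it says the series, first, only, none or still open, it means among the compounds named here.

Measured compounds:
compound 1 `NC(=O)C1CCN(c2nc(-c3cc(F)c(Cl)cc3F)nc3c2CS(=O)(=O)C3)CC1` gives 40000 nM in a physicochemical assay for solubility, with a stated time of 20 h, at pH 6.8; a higher number here means a more soluble compound, a lower number a less soluble compound
compound 2 `NC(=O)CCC1CCN(c2nc(-c3cc(F)c(Cl)cc3F)nc3c2CS(=O)(=O)C3)CC1` gives 8000 nM in this assay
compound 3 `NC(=O)CN1CCN(c2nc(-c3cc(F)c(Cl)cc3F)nc3c2CS(=O)(=O)C3)CC1` gives > 100000 nM in this assay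

For compound 3 the value is a limit of this assay and not a number (the limit of > 100000 nM in this assay, at which 1 of the 3 values shown sits), so compound 3 stands at the top of the numbers shown without a fixed position. Compound 4 `O=S1(=O)Cc2nc(-c3cc(F)c(Cl)cc3F)nc(N3CCC(CCO)CC3)c2C1` differs from compound 3 by 4-(2-hydroxyethyl)piperidin-1-yl in place of 4-(carbamoylmethyl)piperazin-1-yl on an aromatic carbon. Going by the values given here, two measured steps bear on this change: an at least 2.5-fold higher number from compound 1 to compound 3 (0.39 log units; beyond the scatter) and a 5.0-fold lower number from compound 1 to compound 2 (0.70 log units; beyond the scatter). The change to compound 4 undoes the first and lengthens the side chain in the manner of the second, so a lower number than the limit of compound 3 is expected, on the order of an at least 3.3-fold lower number from compound 3 to compound 4 (0.52 log units; beyond the scatter). Compound 4 is estimated at 30000 nM, with a range from 8000 nM to 100000 nM.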

Compound 4, solubility: 23000 nM
Estimate against measurement, compound 4: 1.3-fold (0.12 log units) above; the measured number falls inside the stated range.
By their numbers in this assay, from the lowest: compound 2; then compounds 4 and 1 (each within the scatter of the next). At a limit, above all of these: compound 3.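

With 4-(2-hydroxyethyl)piperidin-1-yl in place of 4-(carbamoylmethyl)piperazin-1-yl on this aromatic carbon, this assay shows an at least 4.3-fold lower number from compound 3 to compound 4 (0.63 log units; beyond the scatter). Compound 3 stands at a limit, not a number: the limit of > 100000 nM in this assay, at which 1 of the 4 values shown sits. Hydroxy in place of carbamoyl on the chain gives a 2.9-fold higher number from compound 2 to compound 4 (0.46 log units; beyond the scatter), whereas 2-hydroxyethyl in place of carbamoyl on the saturated ring carbon gives a 1.7-fold lower number from compound 1 to compound 4 (0.24 log units; within the scatter).

Going by these compounds, whether the step from the piperazine depends on the ring or on the chain end stays open, and 4-(2-hydroxyethyl)piperazin-1-yl would separate the two. On these data alone, how a carboxylic acid or an amine at the chain end would read also remains open.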